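The source may hold more compounds than are shown below. What is called first, only, known or untested is meant among the compounds shown, and "the series" means these compounds.

Of the compounds shown here, three built on one shared core have been measured in an assay on CHO cells for displacement of a labelled ligand from adenosine receptor A1 (Homo sapiens), read by scintillation counting, with a stated time of 60 min, tested at 10 uM; on this read-out lower numbers stand for less inhibition and higher numbers for more inhibition at the one concentration tested (going by the name of the read-out). Compound 1 `CNC(=O)[C@@]12C[C@@H]1[C@@H](n1cnc3c(NC)nc(C#Cc4ccc(-c5ccccc5)cc4)nc31)[C@H](O)[C@@H]2O` gives 18% in this assay, the largest of the three numbers shown, though neither of the other two is separated from it by more than the scatter. Compound 2 `CNC(=O)[C@@]12C[C@@H]1[C@@H](n1cnc3c(NC)nc(C#Cc4cccc(F)c4)nc31)[C@H](O)[C@@H]2O` gives 14%, and compound 3 `CNC(=O)[C@@]12C[C@@H]1[C@@H](n1cnc3c(NC)nc(C#Cc4ccccc4OC)nc31)[C@H](O)[C@@H]2O` gives 12%. The steps between them are all small: a number 4 percentage points lower from compound 1 to compound 2 (within the scatter), a number 6 percentage points lower from compound 1 to compound 3 (within the scatter) and a number 2 percentage points lower from compound 2 to compound 3 (within the scatter). Compound 4 `CNC(=O)[C@@]12C[C@@H]1[C@@H](n1cnc3c(NC)nc(C#Cc4cccnc4)nc31)[C@H](O)[C@@H]2O` has not yet been measured; it differs from compound 1 by pyridin-3-yl in place of 4-phenylphenyl on a triple-bonded carbon. Among the compounds with values here, each measured step likewise exchanges the group on the triple-bonded carbon, and none of them moved the read-out beyond the scatter; none of them, however, brings in a pyridin-3-yl, so no measured step speaks directly to this change. On that basis the step is expected to be a number 5 percentage points lower from compound 1 to compound 4 (within the scatter), that is, nothing beyond the scatter. Compound 4 is therefore estimated to give 13% in this assay, with an expected range from 2% to 26%.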

Compound 4, a percentage reported as inhibition, at one concentration (the size of the read-out at that concentration, not a potency): 16%
Compound 4: the middle estimate sits 3 percentage points below what was measured, and the stated range covers the measured number.
By their numbers in this assay, from the lowest: compounds 3, 2, 4 and 1 (each within the scatter of the next).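

In this assay the pyridin-3-yl group places a ring with a hetero atom on the triple-bonded carbon for the first time among these compounds, and its exchange for 4-phenylphenyl, a change from 12 heavy atoms and two aromatic rings to 6 heavy atoms and one, gives a number 2 percentage points lower from compound 1 to compound 4 (within the scatter) as its step. The comparisons with the other two groups read the same way: a number 4 percentage points higher from compound 3 to compound 4 (within the scatter) and a number 2 percentage points higher from compound 2 to compound 4 (within the scatter) are the remaining steps. Across the four groups shown, neither the size of the group nor a ring nitrogen sets any compound apart from the others. No evidence is at hand that would explain these numbers.

From the compounds shown here alone, all four groups are aromatic rings, so it stays open whether an amine, a carboxylic acid or a longer alkyl chain on the triple-bonded carbon would give a number beyond the scatter. The compounds also leave open what exchanges elsewhere on the shared core would do in this assay at the one concentration tested.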